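Acrylonitrile amides: growth inhibition in MIA cells

A few compounds are considered here, and "the series" means these few. Any claim that something is new, unique, unknown or untested is made for them only; others in the source may bear on it.

Measured compounds:
compound 1 `N#C/C(=C\c1ccc(Cl)cc1)C(=O)c1ccc[nH]1` — 48000 nM
compound 2 `COc1ccc(CNC(=O)/C(C#N)=C/c2ccc[nH]2)cc1` — > 50000 nM
compound 3 `N#C/C(=C\c1ccco1)C(=O)NCc1ccc(Cl)c(Cl)c1` — > 50000 nM

In a functional assay on MIA cells (Homo sapiens) for inhibition, read by MTT assay, with a stated time of 72 h (on this read-out lower numbers stand for stronger inhibition of growth and higher numbers for weaker inhibition of growth), compound 1 gives 48000 nM. For compound 2 only a limit of the assay is known, > 50000 nM. Compound 3 likewise reaches only a limit, > 50000 nM. Among the measured compounds shown here, compound 2 thus stands at the limit of > 50000 nM in this assay, at which 2 of the 3 values shown sit, where compound 3 also sits; compound 1 is the only one with a number, and that number lies close to the same limit.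

Compound 4 `COc1ccc(CNC(=O)/C(C#N)=C/c2ccc(C)o2)cc1` is not yet measured. It differs from compound 2 by 5-methylfuran-2-yl in place of 1H-pyrrol-2-yl on a double-bonded chain carbon bound to a double-bonded chain carbon. For the measured compounds named here, compound 3, which carries a furan-2-yl at the same place, sits at the limit, and no measured step speaks for a change beyond the scatter. Compound 4 is therefore expected to stay weak, at 60000 nM (range 30000 nM to 150000 nM), with the step from compound 2 to compound 4 estimated as a step that the limit leaves unreadable from compound 2 to compound 4 and a limit the most likely outcome.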

Compound 4, concentration for 50% growth inhibition: 51000 nM
For compound 4 the middle estimate is 1.2-fold (0.07 log units) above the measured one; low and high end bracket the measured number.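

No step from compound 2 to compound 4 can be read, because compound 2 has only a limit and no number: the limit of > 50000 nM in this assay, at which 2 of the 4 values shown sit.

From the compounds shown here alone, whether 5-methylfuran-2-yl in place of 1H-pyrrol-2-yl changes growth inhibition at all remains open.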